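Compound 1 Loses Its Acetyl Group

The source may report more compounds than this note shows. Statements on the series, on what has been measured and on what is new or still open speak of the compounds shown alone.

compound 1 `CC[C@H]1CC[C@H](n2c(=O)[nH]c3ncc(NC(C)=O)cc3c2=O)CC1`: 22000 nM
compound 2 `CC[C@H]1CC[C@@H](n2c(=O)[nH]c3ncc(NC(C)=O)cc3c2=O)CC1`: 48000 nM
compound 3 `CC(=O)Nc1cnc2[nH]c(=O)n(CCC3CCCCC3)c(=O)c2c1`: 97000 nM

In a physicochemical assay for solubility, read by nephelometry, measured as kinetic solubility (on this read-out higher numbers stand for higher solubility and lower numbers for lower solubility), compound 1 stands lowest of the three measured compounds, at 22000 nM. The next change leads to compound 4 `CC[C@H]1CC[C@H](n2c(=O)[nH]c3ncc(N)cc3c2=O)CC1`, with hydrogen in place of acetyl on a nitrogen on an aromatic ring, which reads as acetamido to amino: hydrogen in place of acetyl on a nitrogen on an aromatic ring.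

Two measured steps start from compound 1, and both are modest. One is a 2.2-fold higher number from compound 1 to compound 2 (0.34 log units; beyond the scatter), and it goes with the fact that compounds 1 and 2 differ only in the configuration as drawn. The other is a 4.4-fold higher number from compound 1 to compound 3 (0.64 log units; beyond the scatter), where 2-cyclohexylethyl stands in place of 4-ethylcyclohexyl on an aromatic nitrogen. All three measured compounds keep the acetamido group, so neither step measures the present change directly. They serve only as a yardstick for size.

On that yardstick, a modest step is expected in this assay. An upward direction is tentatively expected, since compound 1 has the lowest number of the set at 22000 nM, though this remains uncertain. The expected change is a 2.3-fold higher number from compound 1 to compound 4 (0.36 log units; beyond the scatter). The estimated value for compound 4 is 50000 nM, with an expected range from 15000 nM to 110000 nM.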

Compound 4, solubility: 55000 nM
Compound 4: middle estimate off by 1.1-fold (0.04 log units), on the low side, and the stated range covers the measured number.
By their numbers in this assay, from the lowest: compound 1; then compounds 2, 4 and 3 (each within the scatter of the next, the first and the last beyond it).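

In this assay, hydrogen in place of acetyl on a nitrogen on an aromatic ring gives a 2.5-fold higher number from compound 1 to compound 4 (0.40 log units; beyond the scatter), a modest step that lies beyond the scatter. Within the data shown here, this is the first reading at this nitrogen: compounds 1, 2 and 3 all keep the acetamido group and vary only in configuration or in the group on the aromatic nitrogen, whereas compound 1 and compound 4 differ only in acetamido against amino, with 4-ethylcyclohexyl and its drawn configuration unchanged. It shows that this site also moves the number, and that the amino compound reads higher than its acetamido partner, though no measured property at hand bears on why this step occurs.

The step rests on a single pair, so the compounds shown leave open whether the same change would move the number in the same direction with the configuration of compound 2 or with the 2-cyclohexylethyl group of compound 3. They also leave open how a methylamino group, a longer acyl chain such as propionyl, or a methanesulfonyl group on this nitrogen would read.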